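Shortening a Saturated Chain: Cytotoxicity Toward HEL Cells

The source may report more compounds than this note shows. Statements on the series, on what has been measured and on what is new or still open speak of the compounds shown alone.

Compound 1 `CCCCCCCCNc1nccnc1C(=O)NCc1ccccc1` carries a saturated chain on a nitrogen on an aromatic ring. In an ADME assay on HEL cells (Homo sapiens) for cytotoxicity, read by microscopy, with a stated time of 6 days (a lower number here means that less compound is tolerated, a higher number that more compound is tolerated), compound 1 gives > 100000 nM, which is a limit of the assay and not a number. Compound 2 `CCCCCCNc1cncc(C(=O)NCc2ccccc2)n1` is built on a different core. In this assay compound 2 gives > 100000 nM, again a limit of the assay rather than a number. Among the compounds with values here, both measured values therefore sit at the limit of > 100000 nM in this assay, at which 2 of the 2 values shown sit, so compound 1 stands at the same limit as the only other measured compound, and no step between measured compounds can be drawn from them.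

Compound 3 `CCCCCCNc1nccnc1C(=O)NCc1ccccc1` shares the core of compound 1 and differs from it as hydrogen in place of ethyl on a saturated chain carbon, six bonds along the chain from a nitrogen on an aromatic ring. In this assay the expected step is none beyond the usual scatter, in neither direction, because compound 1 already gives > 100000 nM at the limit. The step this estimate means, a number no higher from compound 1 to compound 3 (the limit leaves the size open), is expected to be flat. Compound 3 is estimated at 100000 nM, with a range from 50000 nM to 200000 nM, and is most likely to be reported again only as a limit.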

Compound 3, minimum cytotoxic concentration: 100000 nM
Estimate against measurement, compound 3: no gap at the digits printed; the range from low to high includes it.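

Compound 3 gives 100000 nM in this assay, so with hydrogen in place of ethyl on a saturated chain carbon, six bonds along the chain from a nitrogen on an aromatic ring, this series now has a value that is a number and not a limit of the assay. The change reads as a number no higher from compound 1 to compound 3 (the limit leaves the size open); its size cannot be read, and the result therefore does not show how much, if at all, removing ethyl at this place alters what the cells tolerate. It does show that the number for this shorter chain lies at the same figure as the limit, and most of the values remain limits: the limit of > 100000 nM in this assay, at which 2 of the 3 values shown sit.

The compounds shown leave open whether a group such as a propyl chain, a longer chain, an amine or a carboxylic acid at this same place would give a number clearly apart from that of compound 3. They also leave open how far compound 1 actually lies from compound 3, since a limit gives no distance to measure.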